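A few compounds are considered here, and "the series" means these few. Any claim that something is new, unique, unknown or untested is made for them only; others in the source may bear on it.

In a functional assay on L1210 (1565) cells (Mus musculus) for cytotoxicity (a higher number here means that more compound is needed for the effect, a lower number that less compound is needed), compound 1 (`CCOc1cc(-c2ccccc2)nc2ccccc12`) gives > 10 ug/mL, which is a limit of the assay and not a number. Compound 2 (`Oc1cc(-c2ccccc2)nc2ccc(Cl)cc12`) gives 0.5 ug/mL, so a measurable value is possible among these compounds. Compound 3 (`CS(=O)(=O)Oc1cc(-c2ccccc2)nc2ccccc12`) carries methylsulfonyl in place of ethyl on an oxygen on an aromatic ring. A modest move towards less compound needed in this assay is expected, the estimated at least 1.6-fold lower number from compound 1 to compound 3 (0.22 log units; that floor lies within the scatter), though a second limit remains possible. The estimate for compound 3 is 6 ug/mL, with an expected range of 1.5 ug/mL to 20 ug/mL.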

Compound 3, half-maximal effective concentration: 6.04 ug/mL
Compound 3: the middle estimate sits 1.0-fold (0.00 log units) below what was measured, within the range that was stated.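

In this assay, methylsulfonyl in place of ethyl on an oxygen on an aromatic ring gives an at least 1.6-fold lower number from compound 1 to compound 3 (0.21 log units; that floor lies within the scatter). Going by these compounds alone, this is the first sign that the group on this oxygen can separate a numerical reading from a limit on the core of compound 1. That step is only a floor, as compound 1 stands at a limit and not a number: the limit of > 10 ug/mL in this assay, at which 1 of the 3 values shown sits.

On these data alone, whether the true step lies beyond the scatter stays open. Also open, as far as these compounds go, is how an acetyl group or a longer chain on this oxygen would read.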